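Compound 4: an amide in place of the urea

A few compounds are considered here, and "the series" means these few. Any claim that something is new, unique, unknown or untested is made for them only; others in the source may bear on it.

Compound 1 `COc1cc(Cl)cc(-c2nn(-c3cccc(NC(=O)Nc4ccc(Cl)c(C(F)(F)F)c4)c3)cc2-c2ccncc2)c1` gives 98% in a functional assay on OVCAR-8 cells (Homo sapiens) for inhibition, read by sulforhodamine B assay, with a stated time of 48 h, tested at 0.01 uM; on this read-out higher numbers stand for a weaker effect at the one concentration tested and lower numbers for a stronger effect. Compound 2 `COc1cc(Cl)cc(-c2nn(-c3cccc(NC(=O)Nc4ccc(Cl)c(Cl)c4)c3)cc2-c2ccncc2)c1` gives 96% in this assay. Compound 3 `COc1cc(Cl)cc(-c2nn(-c3cccc(NC(=O)Nc4cccc(C(F)(F)F)c4)c3)cc2-c2ccncc2)c1` gives 97% in this assay.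

Compound 3 stands second highest of the three numbers, with compound 1 nearest and compound 2 furthest, both within the scatter. Compound 4 `COc1cc(Cl)cc(-c2nn(-c3cccc(NC(=O)c4cccc(C(F)(F)F)c4)c3)cc2-c2ccncc2)c1` differs from compound 3 by 3-(trifluoromethyl)phenyl in place of (3-(trifluoromethyl)phenyl)amino on a carbonyl carbon. For the measured compounds named here, no measured step touches this carbonyl carbon: the steps of a number 2 percentage points lower from compound 1 to compound 2 (within the scatter), a number 1 percentage points lower from compound 1 to compound 3 (within the scatter) and a number 1 percentage points higher from compound 2 to compound 3 (within the scatter) all change groups elsewhere, and all lie within the scatter. With the three measured numbers close together and nothing bearing directly on this change, compound 4 is expected to show no step beyond the scatter, a number 1 percentage points lower from compound 3 to compound 4 (within the scatter). Compound 4 is therefore estimated at 96%, between 82% and 102%.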

Compound 4, a percentage reported as activity, at one concentration (the size of the read-out at that concentration, not a potency): 103%
Estimate against measurement, compound 4: 7 percentage points below; the whole stated range lies below it.
By their numbers in this assay, from the lowest: compounds 2, 3, 1 and 4 (each within the scatter of the next).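

In this assay, replacing the urea with an amide, which takes away the amino nitrogen and its hydrogen-bond donor at this carbonyl carbon, gives no change beyond the scatter with the 3-(trifluoromethyl)phenyl group held constant (a number 6 percentage points higher from compound 3 to compound 4 (within the scatter)). The same holds against the two chlorinated ureas (a number 7 percentage points higher from compound 2 to compound 4 (within the scatter); a number 5 percentage points higher from compound 1 to compound 4 (within the scatter)), so at this one concentration the urea nitrogen is not shown to matter. Nothing available explains this result.

The compounds shown leave open whether a carbamate or thiourea at this position, or a longer alkyl chain in place of the 3-(trifluoromethyl)phenyl, would move the read-out beyond the scatter.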